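The source may report more compounds than this note shows. Statements on the series, on what has been measured and on what is new or still open speak of the compounds shown alone.

Measured so far:
compound 1 `Cc1ccc2nc(C(=O)Nc3c(F)cc(-c4cccc(F)c4)cc3F)c(C)c(C(=O)O)c2c1` — a functional assay on Hep 3B2 cells (Homo sapiens) for antiproliferative activity, read by MTT assay, with a stated time of 24 h, tested at 1.23 ug/mL; a higher number here means a stronger effect of the compound at the concentration tested, a lower number a weaker effect: 21.3%
compound 2 `CCc1ccc2nc(C(=O)Nc3c(F)cc(-c4cccc(F)c4)cc3F)c(C)c(C(=O)O)c2c1` — 4.52%
compound 3 `CCOc1ccc2nc(C(=O)Nc3c(F)cc(-c4cccc(F)c4)cc3F)c(C)c(C(=O)O)c2c1` — 17.9%

Compound 3 stands second highest of the three. Its nearest neighbour is compound 1: a number 3.4 percentage points lower from compound 1 to compound 3 (within the scatter), so the two are not separated. Its furthest is compound 2: a number 13.4 percentage points higher from compound 2 to compound 3 (beyond the scatter), a modest gap that does exceed the scatter.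

Compound 4 `COc1ccc2nc(C(=O)Nc3c(F)cc(-c4cccc(F)c4)cc3F)c(C)c(C(=O)O)c2c1` is the next member. The change from compound 3 is hydrogen in place of methyl on a saturated chain carbon bound to an oxygen on an aromatic ring

Within the data shown here, two measured steps bear on this. The closest in kind is the chain lengthening from compound 1 to compound 2, a number 16.8 percentage points lower from compound 1 to compound 2 (beyond the scatter), which is the same one-carbon difference but run the other way and set on a carbon bound to an aromatic carbon rather than to an oxygen. The step of a number 13.4 percentage points higher from compound 2 to compound 3 (beyond the scatter) concerns the oxygen itself, not chain length, and says less here. Read in reverse, the compound 1 to compound 2 step would suggest shortening the chain raises the read-out somewhat; the different place and the single precedent make this weak. A step about a number 5.1 percentage points higher from compound 3 to compound 4 (within the scatter) is expected, upward but plausibly within the scatter. Compound 4 is estimated at 23%, with a range from 9% to 37%.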

Compound 4, a percentage reported as inhibition, at one concentration (the size of the read-out at that concentration, not a potency): 1.05%
Compound 4: the middle estimate sits 22 percentage points above what was measured, and the stated range ends above it.
By their numbers in this assay, from the lowest: compounds 4 and 2 (each within the scatter of the next); then compounds 3 and 1 (each within the scatter of the next).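

In this assay, the change from ethoxy to methoxy on this aromatic carbon is not a small trim of the chain, as a number 16.9 percentage points lower from compound 3 to compound 4 (beyond the scatter). The effect of the one-carbon difference therefore depends on where it sits, and only the alkoxy pair and the alkyl pair show this, with opposite directions: the same change on two cores in this assay, a number 16.8 percentage points lower (beyond the scatter) from compound 1 to compound 2 and a number 16.9 percentage points higher (beyond the scatter) from compound 4 to compound 3, 33.6 percentage points apart, beyond the scatter of two such steps. The effect of the oxygen also depends on the chain it carries: methoxy in place of methyl gives a number 20.3 percentage points lower from compound 1 to compound 4 (beyond the scatter), whereas methoxy in place of ethyl gives a number 3.5 percentage points lower from compound 2 to compound 4 (within the scatter), which leaves compound 2 and compound 4 unseparated.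

Open, on these data alone, is whether a propoxy chain or an amine on this aromatic carbon would read like the ethoxy group of compound 3 or the methoxy group of compound 4. The reversal rests on a single pair of steps, and these read-outs at one concentration give no potency.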